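Fluoro Added to the Ring of a Transporter Series

The compounds below may be only part of what the source reports. "The series", "measured", "known", "first", "only" and "open" are said of these compounds alone.

Among the compounds with values here, compound 2 `CCCCCCCCCOc1ccc(-c2noc(CCCN)n2)cc1` holds the higher of the two numbers measured so far: in an assay on HeLa cells for inhibition of sphingosine-1-phosphate transporter SPNS2 (Mus musculus), read by LC-MS, tested at 2 uM (on this read-out higher numbers stand for more inhibition at the one concentration tested (going by the name of the read-out) and lower numbers for less inhibition), compound 2 gives 49%, while compound 1 `CCCCCCCCCCc1ccc(-c2noc(CN3CCNCC3)n2)cc1` gives 19% in this assay, a gap beyond the scatter. Compound 3 `CCCCCCCCCOc1ccc(-c2noc(CCCN)n2)cc1F` differs from compound 2 in one place: fluoro in place of hydrogen on an aromatic carbon. Within the data shown here, no single-change step between measured compounds exists here, so the data give no measured size for such a change. The step of a number 1 percentage points higher from compound 2 to compound 3 (within the scatter) is expected to stay within the usual scatter, in no clear direction. Compound 3 is therefore estimated at about 50%, with a range from 30% to 70%.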

Compound 3, a percentage reported as inhibition, at one concentration (the size of the read-out at that concentration, not a potency): 50%
Compound 3: the middle estimate sits on the measured number at the digits printed, and the stated range covers the measured number.
By their numbers in this assay, from the lowest: compound 1; then compounds 2 and 3 (each within the scatter of the next).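

Fluoro in place of hydrogen on this aromatic carbon, ortho to a large group, gives a number 1 percentage points higher from compound 2 to compound 3 (within the scatter) in this assay. The earlier compounds shown here gave no measure of any change at this position, and this step shows that, in this one assay, the position accepts a fluoro group with the two compounds reading alike. Nothing on hand explains why the number holds.

The compounds shown leave open how a larger group on the same carbon, such as chloro, methoxy or an amine, would read. They also leave open how fluoro would read on the other ring carbons.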